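Changing one aromatic group near the assay's limit

This account rests on a few compounds, and the source may have more. Where it says the series, first, only, none or still open, it means among the compounds named here.

Compound 3 `Cc1cc(NC(=O)Nc2ccc(SC(F)(F)F)cc2)c2ccccc2n1` reads > 25000 nM in an ADME assay on BJ cells (Homo sapiens) for cytotoxicity, with a stated time of 72 h (a lower number here means that less compound is needed, a higher number that more compound is needed for the effect), which is a limit of the assay and not a number. Compound 2 `Cc1cc(NC(=O)Nc2ccc(F)cc2)c2ccccc2n1` reads > 25000 nM, also a limit. Compound 1 `CC(=O)c1ccc(NC(=O)Nc2cc(C)nc3ccccc23)cc1` gives an actual number, 22000 nM.

Compound 4 `COc1ccc(NC(=O)Nc2cc(C)nc3ccccc23)cc1` carries methoxy in place of (trifluoromethyl)sulfanyl on an aromatic carbon, para to a large group: methoxy in place of (trifluoromethyl)sulfanyl on an aromatic carbon.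

Three measured steps change this same carbon. They give an at least 1.1-fold higher number from compound 1 to compound 2 (0.05 log units; that floor lies within the scatter) and an at least 1.1-fold higher number from compound 1 to compound 3 (0.05 log units; that floor lies within the scatter). The third is a step that the two limits leave unreadable from compound 2 to compound 3. None of the three shows a change beyond the scatter, although the limits could hide a larger one. In this assay, no step beyond the scatter is therefore expected here, and no direction can be favoured. The expected result is a number no higher from compound 3 to compound 4 (the limit leaves the size open). The estimate for compound 4 is 25000 nM, with an expected range from 12000 nM to 50000 nM.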

Compound 4, half-maximal effective concentration: > 25000 nM
Compound 4 was reported as a limit; the forecaster's own chance of this, stated with the estimate: 60%; the middle value sits exactly at the limit.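

With methoxy on this aromatic carbon, compound 4 reads > 25000 nM in this assay, which is a limit of the assay and not a number. Methoxy is thus a third group, after fluoro and (trifluoromethyl)sulfanyl, that gives no actual number here, and the comparison with acetyl is an at least 1.1-fold higher number from compound 1 to compound 4 (0.05 log units; that floor lies within the scatter), so this new group also shows no change beyond the scatter. The steps to compound 4 from compound 2 and from compound 3 cannot be read, because these compounds all sit at one limit: the limit of > 25000 nM in this assay, at which 3 of the 4 values shown sit.

How far compounds 2, 3 and 4 lie beyond that limit stays open, so any differences among these three remain hidden. Also open, as far as these compounds go, is whether an amine or a carboxylic acid on this carbon would give an actual number in this assay.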